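A few compounds are considered here, and "the series" means these few. Any claim that something is new, unique, unknown or untested is made for them only; others in the source may bear on it.

Measured compounds:
compound 1 `Cc1ccc(NC(=O)Nc2nn(-c3ccccc3)c(=O)c3ccccc23)cc1` — 29%
compound 2 `O=C(Nc1ccccc1)Nc1nn(-c2ccccc2)c(=O)c2ccccc12` — 44%

In an assay on CHO cells for displacement of a labelled ligand from adenosine receptor A1 (Homo sapiens), tested at 10 uM (a higher number here means more inhibition at the concentration tested (going by the name of the read-out), a lower number less inhibition), compound 1 gives 29% and compound 2 gives 44%. Among the measured compounds shown here, compound 2 thus stands highest of the two numbers, its only neighbour being compound 1, which sits lower by a number 15 percentage points higher from compound 1 to compound 2 (beyond the scatter).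

Compound 3 `Cc1ccccc1NC(=O)Nc1nn(-c2ccccc2)c(=O)c2ccccc12` is not yet measured. It differs from compound 2 by methyl in place of hydrogen on an aromatic carbon.

For the measured compounds named here, only one measured step bears on this change: a number 15 percentage points higher from compound 1 to compound 2 (beyond the scatter), which ran in the opposite direction, a methyl leaving an aromatic carbon of the same ring, though at a different place. Read backwards, adding a methyl to that ring cost a modest amount. The methyl now enters ortho to a large group, so the earlier step is only a loose guide, and the expected effect is a modest fall, or none beyond the scatter. Compound 3 is therefore estimated at 35%, with a range of 20% to 50%. The expected step is a number 9 percentage points lower from compound 2 to compound 3 (within the scatter).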

Compound 3, a percentage reported as inhibition, at one concentration (the size of the read-out at that concentration, not a potency): 20%
Beside the measured number, compound 3's estimate is 15 percentage points above it; the measured number falls inside the stated range.
By their numbers in this assay, from the lowest: compounds 3 and 1 (each within the scatter of the next); then compound 2.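

In this assay, a methyl ortho to a large group on the anilino ring gives a number 24 percentage points lower from compound 2 to compound 3 (beyond the scatter), so the inhibition at the concentration tested is lower with the methyl at this place. Exchanging 4-methylphenyl for 2-methylphenyl gives a number 9 percentage points lower from compound 1 to compound 3 (within the scatter), so these two methyl placements are not separated, and both methylated compounds read lower than the unsubstituted compound 2. Nothing available explains the fall seen with the added methyl.

On these data alone, whether the loss is particular to methyl stays open, as a chlorine or a methoxy group at the same place could read differently. Also open, as far as these compounds go, is whether the same change would carry over with a different group on the ring nitrogen of the shared core, such as a benzyl in place of the phenyl.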